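Methylsulfanyl for chloro on the shared core: an estimate

The source may report more compounds than this note shows. Statements on the series, on what has been measured and on what is new or still open speak of the compounds shown alone.

Compound 1 `COc1cc(C)nc2n/c(=N/C(=O)c3c(-c4ccc(Cl)cc4Cl)noc3C)sn12` gives 80.6% in a functional assay on the whole organism for inhibition, with Digitaria ciliaris as the target, with a stated time of 72 h, tested at 100 mg/L; a lower number here means less inhibition of growth, a higher number more inhibition of growth at the concentration tested. Compound 2 `COc1cc(OC)n2s/c(=N\C(=O)c3c(-c4ccc(Cl)cc4Cl)noc3C)nc2n1` gives 85.3%. Compound 3 `COc1cc(Cl)nc2n/c(=N/C(=O)c3c(-c4ccc(Cl)cc4Cl)noc3C)sn12` gives 72.8%.

Compound 3 stands lowest of the three numbers; its gap to compound 1 is within the scatter, its gap to compound 2 beyond it. Compound 4 `COc1cc(SC)nc2n/c(=N/C(=O)c3c(-c4ccc(Cl)cc4Cl)noc3C)sn12` carries methylsulfanyl in place of chloro on an aromatic carbon. Going by the values given here, two measured steps bear on this: a number 7.8 percentage points lower from compound 1 to compound 3 (within the scatter) and a number 12.5 percentage points lower from compound 2 to compound 3 (beyond the scatter), both with chloro entering. Reversing chloro for the two-heavy-atom group with one acceptor is expected to lift compound 4 back toward the level of compound 1 and compound 2, a modest rise at the edge of the scatter, a number 8.2 percentage points higher from compound 3 to compound 4 (within the scatter). Compound 4 is estimated at 81%, between 69% and 91%.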

Compound 4, percent growth inhibition at one concentration: 79.6%
For compound 4 the middle estimate is 1.4 percentage points above the measured one; the measured number falls inside the stated range.
By their numbers in this assay, from the lowest: compounds 3, 4, 1 and 2 (each within the scatter of the next, the first and the last beyond it).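

Methylsulfanyl on this aromatic carbon cannot be told apart from methyl or methoxy: a number 1 percentage points lower from compound 1 to compound 4 (within the scatter), and a number 5.7 percentage points lower from compound 2 to compound 4 (within the scatter). Against chloro too, the change stays inside the scatter, with a number 6.8 percentage points higher from compound 3 to compound 4 (within the scatter), so this position accepts a sulfur-linked group without a loss beyond the scatter. Nothing available explains these numbers.

On these data alone, whether an amine or a longer chain such as butylsulfanyl at this position would hold growth inhibition at this level remains open. So does whether any replacement here can move the read-out clearly beyond the scatter from methoxy, other than chloro.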